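Opening a four-membered ring at the chain end

This account rests on a few compounds, and the source may have more. Where it says the series, first, only, none or still open, it means among the compounds named here.

Of the compounds shown here, three sharing one core have been measured in a functional assay on KG-1 cells (Homo sapiens) for antiproliferative activity; a lower number here means that less compound is needed, a higher number that more compound is needed for the effect. Compound 1 `CC(O)CC#Cc1c(Cl)c2c(Cl)cc(C(N)=O)nc2n1[C@H]1CCCNC1` carries a 1-hydroxyethyl group on a saturated chain carbon bound to a triple-bonded carbon, and in this assay compound 1 gives 48 nM. Compound 2 `COCCC#Cc1c(Cl)c2c(Cl)cc(C(N)=O)nc2n1[C@H]1CCCNC1` carries methoxymethyl at that place, and compound 2 gives 39 nM; the step of a 1.2-fold lower number from compound 1 to compound 2 (0.09 log units; within the scatter) lies within the scatter. Compound 3 `CC1(CC#Cc2c(Cl)c3c(Cl)cc(C(N)=O)nc3n2[C@H]2CCCNC2)COC1` carries 3-methyloxetan-3-yl there and gives 289 nM, the highest of the three numbers, with a 6.0-fold higher number from compound 1 to compound 3 (0.78 log units; beyond the scatter) and a 7.4-fold higher number from compound 2 to compound 3 (0.87 log units; beyond the scatter) both beyond the scatter.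

Compound 4 `COC(C)(C)CC#Cc1c(Cl)c2c(Cl)cc(C(N)=O)nc2n1[C@H]1CCCNC1` is the next step: 1-methoxy-1-methylethyl in place of 3-methyloxetan-3-yl on a saturated chain carbon bound to a triple-bonded carbon. Both groups hold one oxygen and no hydrogen-bond donor, but the ring of compound 3 is gone and an open chain stands in its place, as in compound 1 and compound 2. Those two open-chain compounds gave the lower numbers, and the two steps from them to compound 3 were modest and beyond the scatter. The step from compound 3 to compound 4 is therefore expected to run back in the opposite direction, a 4.4-fold lower number from compound 3 to compound 4 (0.65 log units; beyond the scatter), toward the numbers of compound 1 and compound 2. Compound 4 is estimated at 65 nM, within a range from 25 nM to 170 nM.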

Compound 4, half-maximal effective concentration: 172 nM
Estimate against measurement, compound 4: 2.6-fold (0.42 log units) below; measured number above the stated range.
By their numbers in this assay, from the lowest: compounds 2 and 1 (each within the scatter of the next); then compounds 4 and 3 (each within the scatter of the next).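

In this assay, opening the four-membered ring does not by itself restore the lower numbers: the step from the oxetane to its open-chain counterpart, a 1.7-fold lower number from compound 3 to compound 4 (0.23 log units; within the scatter), lies within the scatter, so this change at the saturated chain carbon bound to a triple-bonded carbon cannot be read as having any effect. The open chain of compound 4 still stands apart from the other two open chains, with a 4.4-fold higher number from compound 2 to compound 4 (0.64 log units; beyond the scatter) and a 3.6-fold higher number from compound 1 to compound 4 (0.55 log units; beyond the scatter), both beyond the scatter, so among these four compounds the division follows whether the group is attached through a fully substituted carbon, as in compounds 3 and 4, rather than whether it holds a ring, and none of the four goes against this. Nothing available explains why these groups divide in this way.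

The compounds shown leave open whether the fully substituted carbon alone marks the division, or whether its combination with the ether oxygen matters, a question that 1-hydroxy-1-methylethyl or tert-butyl at this place would address. They also leave open how an amine such as dimethylaminomethyl or a longer chain such as 2-methoxyethyl would behave here.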